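This account rests on a few compounds, and the source may have more. Where it says the series, first, only, none or still open, it means among the compounds named here.

Of the compounds shown here, three sharing one core have been measured in a functional assay on MIA PaCa-2 cells (Homo sapiens) for inhibition, read by MTT assay, with a stated time of 72 h; a higher number here means a weaker inhibitor of growth, a lower number a stronger inhibitor of growth. Compound 3 `COc1ccc(CNCCCNS(=O)(=O)c2cc(C(F)(F)F)cc(C(F)(F)F)c2)cc1` gives 2500 nM. Compound 2 `CC(C)(C)c1ccc(CNCCCNS(=O)(=O)c2cc(C(F)(F)F)cc(C(F)(F)F)c2)cc1` gives 2300 nM, and the two numbers lie within the scatter of each other, as a 1.1-fold higher number from compound 2 to compound 3 (0.04 log units; within the scatter) shows. Compound 1 `O=S(=O)(NCCCNCc1ccccc1Cl)c1cc(C(F)(F)F)cc(C(F)(F)F)c1` gives 11000 nM, the highest of the three; the step of a 4.4-fold lower number from compound 1 to compound 3 (0.64 log units; beyond the scatter) is beyond the scatter, as is a 4.8-fold lower number from compound 1 to compound 2 (0.68 log units; beyond the scatter). Compound 4 `O=S(=O)(NCCCNCc1cccc(Cl)c1)c1cc(C(F)(F)F)cc(C(F)(F)F)c1` has not yet been measured. It differs from compound 3 in one place: 3-chlorophenyl in place of 4-methoxyphenyl on a saturated chain carbon bound to an amine nitrogen. Among the measured compounds shown here, no measured step has this exact change. For the measured compounds named here, the steps that bear on it are a 4.4-fold lower number from compound 1 to compound 3 (0.64 log units; beyond the scatter) and a 4.8-fold lower number from compound 1 to compound 2 (0.68 log units; beyond the scatter), which show that the 2-chlorophenyl of compound 1 gave a higher number than either the 4-methoxyphenyl or the 4-(tert-butyl)phenyl. Compound 4 carries a 3-chlorophenyl rather than the 2-chlorophenyl of compound 1, so its number is expected to move toward that of compound 1 without necessarily reaching it. The expected step is a 2.2-fold higher number from compound 3 to compound 4 (0.34 log units; beyond the scatter). Compound 4 is estimated at 5500 nM, with a range from 2000 nM to 15000 nM.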

Compound 4, concentration for 50% growth inhibition: 4400 nM
Beside the measured number, compound 4's estimate is 1.3-fold (0.10 log units) above it; the measured number falls inside the stated range.
By their numbers in this assay, from the lowest: compounds 2, 3 and 4 (each within the scatter of the next); then compound 1.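

In this assay, the 2-chlorophenyl and 3-chlorophenyl groups differ only in where the chlorine sits on the ring, yet a 2.5-fold lower number from compound 1 to compound 4 (0.40 log units; beyond the scatter), so at this position the placement of the chlorine changes the number. Chlorine on the ring does not by itself set a compound apart from the others: a 1.8-fold higher number from compound 3 to compound 4 (0.25 log units; within the scatter) and a 1.9-fold higher number from compound 2 to compound 4 (0.28 log units; within the scatter), so the 3-chlorophenyl cannot be separated from the 4-methoxyphenyl or the 4-(tert-butyl)phenyl, and among these four groups only the 2-chlorophenyl stands apart. Nothing measured here explains this difference.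

The compounds shown leave open how a 4-chlorophenyl or a plain phenyl would compare at this position. They also leave open what a longer chain linking the amine to the sulfonamide would do.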